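The compounds below may be only part of what the source reports. "The series", "measured", "known", "first", "only" and "open" are said of these compounds alone.

Measured compounds:
compound 1 `COC(=O)[C@@]1(C)CC[C@@H]2C3=C1CC[C@@H](C)[C@]3(C)Cc1c2[nH]c2ccccc12` – in a functional assay on T47D cells (Homo sapiens) for inhibition, read by sulforhodamine B assay, with a stated time of 48 h (on this read-out higher numbers stand for weaker inhibition of growth and lower numbers for stronger inhibition of growth), compound 1 gives 3400 nM
compound 2 `COC(=O)[C@@]1(C)CC[C@@H]2C3=C1CC[C@@H](C)[C@]3(C)Cc1c2[nH]c2ccc(Br)cc12` – in this assay compound 2 gives 21000 nM
compound 3 `COC(=O)[C@@]1(C)CC[C@@H]2C3=C1CC[C@@H](C)[C@]3(C)Cc1c2[nH]c2ccc(OC)cc12` – in this assay compound 3 gives 6500 nM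

Compound 1 has the lowest number of the three in this assay. Its nearest neighbour is compound 3, a 1.9-fold higher number from compound 1 to compound 3 (0.28 log units; within the scatter), a step within the scatter that allows no ranking between the two. Compound 2 stands furthest away, a 6.2-fold higher number from compound 1 to compound 2 (0.79 log units; beyond the scatter), a modest step beyond the scatter. Between the two substituted analogues, a 3.2-fold lower number from compound 2 to compound 3 (0.51 log units; beyond the scatter).

Compound 4 `COC(=O)[C@@]1(C)CC[C@@H]2C3=C1CC[C@@H](C)[C@]3(C)Cc1c2[nH]c2c(Br)cccc12` is not yet measured. It differs from compound 1 by bromo in place of hydrogen on an aromatic carbon. For the measured compounds named here, the only measured step with the same entering group is a 6.2-fold higher number from compound 1 to compound 2 (0.79 log units; beyond the scatter), modest and toward weaker inhibition; in compound 2 the bromo sits at a different place on the same ring, so its bearing here is indirect, and no measured step tests this place directly. A step toward a higher number, of a size comparable to or somewhat smaller than that seen with compound 2, is expected. On this basis compound 4 is estimated at 12000 nM in this assay, with a range of 4000 nM to 35000 nM, which corresponds to an expected 3.5-fold higher number from compound 1 to compound 4 (0.55 log units; beyond the scatter).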

Compound 4, concentration for 50% growth inhibition: 31000 nM
Compound 4: the middle estimate sits 2.6-fold (0.41 log units) below what was measured; low and high end bracket the measured number.
By their numbers in this assay, from the lowest: compounds 1 and 3 (each within the scatter of the next); then compounds 2 and 4 (each within the scatter of the next).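

In this assay, bromo in place of hydrogen on this aromatic carbon, ortho to a fused ring, gives a 9.1-fold higher number from compound 1 to compound 4 (0.96 log units; beyond the scatter), a modest step toward weaker inhibition of growth. The direction seen with compound 2 therefore holds at a second place on the six-membered aromatic ring, so the step is not confined to one carbon of that ring; compound 2 and compound 4 stand within the scatter of each other, and these numbers do not separate the two places. Nothing at hand bears on the reason for this step.

Open, from the compounds shown here alone, is whether the step belongs to bromo or to any group entering at this carbon, since methoxy appears only at the place it holds in compound 3. A fluoro group, an amine or a carboxylic acid on this carbon would show whether the shared core accepts any substituent here without a step toward weaker inhibition, or whether hydrogen remains the best-placed atom at this position of the series.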